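The compounds below may be only part of what the source reports. "The series", "measured", "known", "first", "only" and "open" are said of these compounds alone.

Measured compounds in a functional assay on RXF 393 cells (Homo sapiens) for cytotoxicity, read by sulforhodamine B assay, with a stated time of 48 h, tested at 0.1 uM; a lower number here means a stronger effect, a higher number a weaker effect of the compound at the concentration tested:
compound 1 `COc1cc(-c2cc(/C=C/C(=O)c3ccc(N)cc3)[nH]n2)cc(OC)c1OC`: 91%
compound 2 `COc1ccc(C(=O)/C=C/c2cc(-c3cc(OC)c(OC)c(OC)c3)n[nH]2)cc1OC`: 100%

Compound 2 stands highest of the two numbers in this assay, but its nearest neighbour, compound 1, lies within the scatter of it, so the two are not told apart.

Compound 3 `COc1cc(-c2cc(/C=C/C(=O)c3ccc(F)c(F)c3)[nH]n2)cc(OC)c1OC` is not yet measured. It differs from compound 2 in one place: 3,4-difluorophenyl in place of 3,4-dimethoxyphenyl on a carbonyl carbon. Among the compounds with values here, the only measured step, a number 9 percentage points higher from compound 1 to compound 2 (within the scatter), changes the same aryl group on the carbonyl carbon and stays within the scatter; it does not involve a 3,4-difluorophenyl, so it gives no direct precedent for the step to compound 3 and only shows that this position tolerated one exchange without a shift. No step beyond the scatter is therefore expected in this assay, a number 5 percentage points lower from compound 2 to compound 3 (within the scatter).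

Compound 3 is estimated at 95% in this assay, in the range 78% to 108%.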

Compound 3, a percentage reported as activity, at one concentration (the size of the read-out at that concentration, not a potency): 96%
The estimate for compound 3 lay 1 percentage points below the measured number, within the range that was stated.
By their numbers in this assay, from the lowest: compounds 1, 3 and 2 (each within the scatter of the next).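

The exchange of 3,4-dimethoxyphenyl for 3,4-difluorophenyl on the carbonyl carbon gives a number 4 percentage points lower from compound 2 to compound 3 (within the scatter) in this assay, and the exchange of 4-aminophenyl for 3,4-difluorophenyl gives a number 5 percentage points higher from compound 1 to compound 3 (within the scatter). Within the data shown here, three aryl groups at this place are thus not told apart, even though the 2 hydrogen-bond acceptors counted on 3,4-dimethoxyphenyl are absent from 3,4-difluorophenyl, which has 0; the earlier pair offered only one exchange here. No measurement on hand bears on this result.

The compounds shown leave open whether any group on the carbonyl carbon separates from these three, such as a carboxylic acid on the phenyl ring or a plain methyl in place of the ring. They also leave open whether changing the rest of the shared core would move the read-out.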